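The source may hold more compounds than are shown below. What is called first, only, known or untested is meant among the compounds shown, and "the series" means these compounds.

Two compounds share one core and differ in the group hanging off the far aromatic ring. Compound 1 `O=C(COc1cccc2ccccc12)N/N=C/c1ccc(O)cc1` carries a hydroxy there, and in an ADME assay on HEL cells (Homo sapiens) for cytotoxicity (on this read-out higher numbers stand for lower toxicity in this test and lower numbers for higher toxicity in this test), compound 1 gives 20 ug/mL. Compound 2 `C/C(=N\NC(=O)COc1cccc2ccccc12)c1ccc([N+](=O)[O-])cc1` carries a nitro and a methyl on its imine carbon, and in this assay compound 2 gives 100 ug/mL. Among these two numbers compound 1 stands lowest, with compound 2 as its only neighbour at a number that lies beyond the scatter.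

Compound 3 `Cc1ccc(/C=N/NC(=O)COc2cccc3ccccc23)cc1` is not yet measured. It differs from compound 1 by one change, (methyl in place of hydroxy on an aromatic carbon), on an aromatic carbon of a six-membered aromatic ring of carbon only. Going by the values given here, no measured pair shows this change, so the expected step is uncertain; a small rise in this assay, possibly within the scatter, seems most likely, written as a 2.0-fold higher number from compound 1 to compound 3 (0.30 log units; within the scatter). Compound 3 is therefore estimated at 40 ug/mL, between 15 ug/mL and 100 ug/mL.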

Compound 3, minimum cytotoxic concentration: 20 ug/mL
The estimate for compound 3 lay 2.0-fold (0.30 log units) above the measured number, within the range that was stated.
By their numbers in this assay, from the lowest: compounds 1 and 3 (each within the scatter of the next); then compound 2.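

In this assay, going from 4-hydroxyphenyl to 4-methylphenyl gives no change at the digits printed from compound 1 to compound 3 (within the scatter) as the only difference. At this place, on an aromatic carbon para to a large group, the hydroxy with its hydrogen-bond donor and acceptor can therefore give way to a methyl, which has neither, without a change in this read-out, something compound 2 could not show because it differs from compound 1 in more than one place. No measurement here offers a reason why the two groups read alike.

As far as these compounds go, whether other groups at this place behave the same stays open: an amine, a carboxylic acid or a longer chain could give a different number. Compound 2 also carries both a nitro and a methyl on its imine carbon, so the contribution of each to its number cannot be separated.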